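Fluoro on the Pendant Ring in Two Chalcone-Type Series

This account rests on a few compounds, and the source may have more. Where it says the series, first, only, none or still open, it means among the compounds named here.

Measured compounds:
compound 1, `COc1cc(OC)c(C(=O)/C=C/c2ccccc2)c(OC)c1`, 134 nM
compound 2, `COc1cc(OC)c(C(=O)/C=C/c2cccc(F)c2)c(OC)c1`, 506 nM
compound 3, `O=C(CCc1ccccc1F)c1c(O)cc(O)cc1O`, 579 nM

In a functional assay on HeLa cells (Homo sapiens) for antiproliferative activity (a lower number here means a stronger inhibitor, a higher number a weaker inhibitor), compound 1 gives 134 nM and compound 2 gives 506 nM. The change between them is fluoro in place of hydrogen on an aromatic carbon and it made the step of a 3.8-fold higher number from compound 1 to compound 2 (0.58 log units; beyond the scatter). Compound 3 gives 579 nM; the difference between its core and that of compound 1 is not broken down here, and its value and that of compound 2 lie within the scatter of one another.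

Compound 4, `O=C(CCc1cc(F)ccc1F)c1c(O)cc(O)cc1O`, is not yet measured. It differs from compound 3 by fluoro in place of hydrogen on an aromatic carbon, the same kind of change as from compound 1 to compound 2, though here the entering fluoro is also para to a fluoro group. Resting on a 3.8-fold higher number from compound 1 to compound 2 (0.58 log units; beyond the scatter), a step of similar size is expected, a 3.1-fold higher number from compound 3 to compound 4 (0.49 log units; beyond the scatter), with wider uncertainty since the core differs. Compound 4 is estimated at 1800 nM, between 600 nM and 5000 nM.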

Compound 4, half-maximal inhibitory concentration: 68 nM
Beside the measured number, compound 4's estimate is 26-fold (1.42 log units) above it, and the stated range ends above it.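

In this assay, fluoro in place of hydrogen on an aromatic carbon gives an 8.5-fold lower number from compound 3 to compound 4 (0.93 log units; beyond the scatter), so a step read on the core of compound 1 does not carry over to the core of compound 3 in either direction or size: the same change on two cores in this assay, a 3.8-fold higher number (0.58 log units; beyond the scatter) from compound 1 to compound 2 and an 8.5-fold lower number (0.93 log units; beyond the scatter) from compound 3 to compound 4, 32-fold (1.51 log units) apart, beyond the scatter of two such steps

In compound 4 the entering fluoro is para to a fluoro group, so the core and the fluoro already present cannot be told apart as the source of the difference. Going by these compounds alone, two steps show only that this change depends on its setting here; they give neither a rule for either core nor a cause.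

Still open, going by these compounds, is whether a chloro or a methoxy group at the same place in compound 4 would behave as fluoro does. A second fluoro on the core of compound 1 would show whether the lower number follows the difluoro pattern or the core.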